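This account rests on a few compounds, and the source may have more. Where it says the series, first, only, none or still open, it means among the compounds named here.

In a functional assay on HT cells (Homo sapiens) for antiproliferative activity, read by fluorescence, with a stated time of 72 h (a lower number here means a stronger inhibitor of growth, a higher number a weaker inhibitor of growth), compound 1 (`CC(C)c1n[nH]c2c(NCc3ccc(-c4ccccn4)cc3)nc(SCC3CNC(=O)O3)nc12`) gives 80 nM, compound 2 (`CC(C)c1n[nH]c2c(NCc3ccc(-c4ccccn4)cc3)nc(SCC(O)CN3CCNCC3)nc12`) gives 332 nM and compound 3 (`CC(C)c1n[nH]c2c(NCc3ccc(-c4ccccn4)cc3)nc(SC(CO)C(C)C)nc12`) gives 980 nM. The three share one core and differ only in the group on the sulfur. Compound 3 has the highest number of the three, which makes it the weakest inhibitor of growth in this small set. Two steps beyond the scatter show this: a 12-fold higher number from compound 1 to compound 3 (1.09 log units; beyond the scatter) is large and a 3.0-fold higher number from compound 2 to compound 3 (0.47 log units; beyond the scatter) is modest.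

Compound 4 (`CC(C)c1n[nH]c2c(NCc3ccc(-c4ccccn4)cc3)nc(SCCN)nc12`) changes that same group, with 2-aminoethyl in place of 1-(hydroxymethyl)-2-methylpropyl on a sulfur. Among the compounds with values here, no measured step makes exactly this swap, so the evidence is indirect. Within the data shown here, the nearest guide is compound 2, the only measured compound whose chain also carries an amine, here within a piperazin-1-yl group, at 332 nM. Compound 1 has no such amine, and a 4.2-fold higher number from compound 1 to compound 2 (0.62 log units; beyond the scatter) shows that an amine-bearing chain need not give the lowest number. Among the measured compounds shown here, a modest move towards compound 2 therefore seems more likely than a large gain, and the short chain has no direct precedent here. The expected change is a 3.3-fold lower number from compound 3 to compound 4 (0.51 log units; beyond the scatter), towards stronger growth inhibition. For compound 4 the estimate is 300 nM, with an expected range of 100 nM to 900 nM.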

Compound 4, concentration for 50% growth inhibition: 22 nM
Compound 4: the middle estimate sits 14-fold (1.13 log units) above what was measured; the whole stated range lies above it.
By their numbers in this assay, from the lowest: compound 4; then compound 1; then compound 2; then compound 3.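

Compound 4, with 2-aminoethyl on the sulfur, is the strongest inhibitor of growth of the four in this assay, and all three of its steps lie beyond the scatter: the large (a 45-fold lower number from compound 3 to compound 4 (1.65 log units; beyond the scatter)), the equally large (a 15-fold lower number from compound 2 to compound 4 (1.18 log units; beyond the scatter)) and the modest (a 3.6-fold lower number from compound 1 to compound 4 (0.56 log units; beyond the scatter)). This shows that the larger groups on the sulfur are not needed for a low number, and that a small unbranched chain of 3 heavy atoms ending in an amine outdoes every other group shown, although compound 2 goes against any simple rule that an amine on the chain gives a low number. Nothing shown explains why this short amine chain stands out.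

The compounds shown leave open whether the gain belongs to the amine or to the short unbranched chain, as the change from compound 3 to compound 4 alters both at once. A 2-hydroxyethyl group on the sulfur would test the amine at the same chain length, while a 3-aminopropyl group, a longer chain with the same amine, would test the length.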